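Swapping Chloro for Cyano: What to Expect

This account rests on a few compounds, and the source may have more. Where it says the series, first, only, none or still open, it means among the compounds named here.

Compound 1 `Cc1ccccc1C(=O)Nc1cc(Cl)ccn1`: 12.5 ug/mL
Compound 2 `Cc1c(F)cccc1C(=O)Nc1cc(Cl)ccn1`: 12.5 ug/mL

In a physicochemical assay for solubility, read by nephelometry, measured as kinetic solubility, at pH 6.5, tested at 10 mg/mL (on this read-out lower numbers stand for lower solubility and higher numbers for higher solubility), compound 1 gives 12.5 ug/mL, and it stands level with compound 2 at 12.5 ug/mL. Compound 3 `Cc1ccccc1C(=O)Nc1cc(C#N)ccn1` has not yet been measured. It differs from compound 1 in one place: cyano in place of chloro on an aromatic carbon. In plain terms, this is cyano in place of chloro on an aromatic carbon. Within the data shown here, only one measured step is available as a guide: no change at the digits printed from compound 1 to compound 2 (within the scatter). That step is a different exchange, fluoro in place of hydrogen, so it bears on this question only loosely. Among the measured compounds shown here, no measured step involves the chloro group, so the data point in neither direction, and no shift beyond the usual scatter is expected. The expected step is a 1.2-fold higher number from compound 1 to compound 3 (0.08 log units; within the scatter). For compound 3 the estimated value is 15 ug/mL, with an expected range of 6 ug/mL to 40 ug/mL.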

Compound 3, solubility: 25 ug/mL
Estimate against measurement, compound 3: 1.7-fold (0.22 log units) below, and the stated range covers the measured number.
By their numbers in this assay, from the lowest: compounds 1, 2 and 3 (each within the scatter of the next).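

In this assay, putting cyano in place of chloro on an aromatic carbon, opposite the ring nitrogen, gives a 2.0-fold higher number from compound 1 to compound 3 (0.30 log units; within the scatter). This is the first step shown at this position, since the earlier step between compounds concerned fluoro at a different place, so it shows that this exchange, which brings in a triple bond and a hydrogen-bond acceptor, keeps the reading within the usual scatter. No separate measurement here speaks to why the reading lands where it does.

The compounds shown leave open how an amine or a carboxylic acid at this same position would read in this assay. Also open, as far as these compounds go, is whether cyano in place of chloro would give a similar step on compound 2, which carries the fluoro group.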